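A few compounds are considered here, and "the series" means these few. Any claim that something is new, unique, unknown or untested is made for them only; others in the source may bear on it.

Going by the values given here, in a functional assay on LOX IMVI cells (Homo sapiens) for inhibition, read by colorimetric assay and sulforhodamine B assay, with a stated time of 48 h (on this read-out lower numbers stand for stronger inhibition of growth and higher numbers for weaker inhibition of growth), three amides on one shared core have numbers so far. Compound 1 `CCCCCCCCCCCC[C@@H](O)[C@H]1CC[C@H]([C@H](O)CCCCCCCCCCNC(=O)c2ccco2)O1` gives 17000 nM, and compound 2 `CCCCCCCCCCCC[C@@H](O)[C@H]1CC[C@H]([C@H](O)CCCCCCCCCCNC(=O)c2ccoc2)O1` gives 21900 nM. The two furan amides lie within the scatter of each other, with a 1.3-fold higher number from compound 1 to compound 2 (0.11 log units; within the scatter). Compound 3 `CCCCCCCCCCCC[C@@H](O)[C@H]1CC[C@H]([C@H](O)CCCCCCCCCCNC(=O)c2ccsc2)O1` gives 1510 nM, the lowest of the three numbers, and it stands clearly apart from both furans. The steps are large and beyond the scatter: an 11-fold lower number from compound 1 to compound 3 (1.05 log units; beyond the scatter) and a 15-fold lower number from compound 2 to compound 3 (1.16 log units; beyond the scatter).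

Compound 4 `CCCCCCCCCCCC[C@@H](O)[C@H]1CC[C@H]([C@H](O)CCCCCCCCCCNC(=O)c2ccnn2C)O1` has not yet been measured. It has 1-methyl-1H-pyrazol-5-yl in place of thiophen-3-yl on a carbonyl carbon. Among the compounds with values here, no measured compound carries this group, so the evidence is indirect. Within the data shown here, the only guides are the two steps that link compound 3 to compound 1 and compound 2, an 11-fold lower number from compound 1 to compound 3 (1.05 log units; beyond the scatter) and a 15-fold lower number from compound 2 to compound 3 (1.16 log units; beyond the scatter). In both, the compound without thiophen-3-yl has the higher number. A move away from thiophen-3-yl is therefore expected to raise the number, by somewhat less than those steps, though with wide uncertainty. The estimated change is a 7.3-fold higher number from compound 3 to compound 4 (0.86 log units; beyond the scatter). For compound 4 the estimated value is 11000 nM, with an expected range from 2500 nM to 40000 nM.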

Compound 4, concentration for 50% growth inhibition: 10 nM
Beside the measured number, compound 4's estimate is 1100-fold (3.04 log units) above it, and the stated range ends above it.
By their numbers in this assay, from the lowest: compound 4; then compound 3; then compounds 1 and 2 (each within the scatter of the next).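

In this assay, the group on the carbonyl carbon of the amide turns out to control growth inhibition far more strongly than the furan and thiophene amides could show: 1-methyl-1H-pyrazol-5-yl in place of thiophen-3-yl gives a 150-fold lower number from compound 3 to compound 4 (2.18 log units; beyond the scatter), and the same group gives a 2200-fold lower number from compound 2 to compound 4 (3.34 log units; beyond the scatter) and a 1700-fold lower number from compound 1 to compound 4 (3.23 log units; beyond the scatter). Thiophen-3-yl therefore no longer marks the low end at this position, and compound 4 is the most potent of the four, with all of its steps beyond the scatter. The change replaces a ring with one hetero atom by a methyl-bearing ring with two, so several features differ at once, and nothing given here accounts for the size of the step.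

The compounds shown leave open whether the methyl group matters, which the unmethylated 1H-pyrazol-5-yl amide would address, and whether the placement of the ring atoms matters, which 1-methyl-1H-pyrazol-4-yl or 1-methyl-1H-imidazol-5-yl amides would address. They also leave open whether the gain from the 1-methyl-1H-pyrazol-5-yl group would survive on a shorter chain than the one shared by these four compounds.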